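The compounds below may be only part of what the source reports. "The series", "measured", "known", "first", "only" and "open" are said of these compounds alone.

Compound 1, `COc1cc(Cl)cc(-c2nn(-c3cccc(NC(=O)Nc4ccc(Cl)c(C(F)(F)F)c4)c3)cc2-c2ccncc2)c1`, gives 75% in a functional assay on SF-539 cells (Homo sapiens) for inhibition, read by sulforhodamine B assay, with a stated time of 48 h, tested at 1 uM; a higher number here means a weaker effect of the compound at the concentration tested, a lower number a stronger effect.
Compound 2, `COc1cc(Cl)cc(-c2nn(-c3cccc(NC(=O)Nc4cccc(C(F)(F)F)c4)c3)cc2-c2ccncc2)c1`, gives 84% in this assay.

Within the data shown here, compound 2 holds the higher of the two numbers, yet the one measured step, a number 9 percentage points higher from compound 1 to compound 2 (within the scatter), lies within the scatter, so the two compounds cannot be told apart on these numbers. Compound 3, `COc1cc(Cl)cc(-c2nn(-c3cccc(NC(=O)c4cccc(C(F)(F)F)c4)c3)cc2-c2ccncc2)c1`, is the unmeasured compound. It differs from compound 2 in one place: 3-(trifluoromethyl)phenyl in place of (3-(trifluoromethyl)phenyl)amino on a carbonyl carbon. Among the measured compounds shown here, no measured step speaks to this kind of change. For the measured compounds named here, the only step that is known, a number 9 percentage points higher from compound 1 to compound 2 (within the scatter), swaps a chloro for hydrogen on an aromatic ring and leaves the carbonyl untouched, so it gives no guide here. With nothing in the data pointing either way, the expectation for compound 3 is that the number stays close to that of compound 2, with no step beyond the scatter, which is expressed as no change at the digits printed from compound 2 to compound 3 (within the scatter). Going by the values given here, for compound 3 the estimate is therefore 84%, within a range from 62% to 100%, the width of the range reflecting that no measured step informs this change.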

Compound 3, a percentage reported as activity, at one concentration (the size of the read-out at that concentration, not a potency): 52%
Compound 3: middle estimate off by 32 percentage points, on the high side; the whole stated range lies above it.
By their numbers in this assay, from the lowest: compound 3; then compounds 1 and 2 (each within the scatter of the next).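

The group on this carbonyl carbon matters in a way the chloro swap did not show. In this assay, replacing (3-(trifluoromethyl)phenyl)amino with 3-(trifluoromethyl)phenyl gives a large change (a number 32 percentage points lower from compound 2 to compound 3 (beyond the scatter)). A lower number means a stronger effect, and the change favours compound 3. The comparison with the chlorinated partner points the same way, though the step is modest (a number 23 percentage points lower from compound 1 to compound 3 (beyond the scatter)), and in this change the amino nitrogen leaves and takes a hydrogen-bond donor with it, while the ring and its trifluoromethyl group stay; nothing measured here gives a reason for the lower number.

As far as these compounds go, it remains open whether the nitrogen as a whole or only its hydrogen is tied to this step, and a methylamino or an oxygen link in the same place could help separate the two. Among these compounds, also open is how 4-chloro-3-(trifluoromethyl)phenyl would read attached straight to the carbonyl carbon, since the chloro step so far has been seen only with the amino group in place.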